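This account rests on a few compounds, and the source may have more. Where it says the series, first, only, none or still open, it means among the compounds named here.

Compound 1, `CCCn1c(-c2ccc(OCc3c(-c4c(Cl)cccc4Cl)noc3C(C)C)cc2)nc2ccc(C(=O)O)cc21`, gives 1400 nM in an assay on HEK-293T cells for antagonist activity at vitamin D3 receptor (Homo sapiens), read by a luciferase reporter, with a stated time of 24 h; a higher number here means a weaker inhibitor, a lower number a stronger inhibitor.
Compound 2, `CC(C)c1onc(-c2c(Cl)cccc2Cl)c1COc1ccc(-c2nc3ccc(C(=O)O)cc3n2CC2CCCCC2)c(Cl)c1`, gives 160 nM in this assay.
Compound 3, `CC(C)c1onc(-c2c(Cl)cccc2Cl)c1COc1ccc(-c2nc3ccc(C(=O)O)cc3n2C)cc1Cl`, gives 2450 nM in this assay.

Among these three compounds, compound 1 stands second highest. Its nearest neighbour is compound 3, whose number is a little higher but within the usual scatter of repeated measurements, so the two cannot be ranked against each other. Compound 2 lies furthest away, with a clearly lower number, beyond the scatter, so compound 2 is the stronger inhibitor of the pair. Compound 4, `CC(C)c1onc(-c2c(Cl)cccc2Cl)c1COc1ccc(-c2nc3ccc(C(=O)O)cc3n2C2CCCCC2)cc1`, has not yet been measured. It differs from compound 1 in one place: cyclohexyl in place of propyl on an aromatic nitrogen. Going by the values given here, no single-point step between two measured compounds exists here to guide the size of this change, so the expectation rests on the wider picture only. Compound 2, which carries a larger group on the same ring nitrogen together with a second change elsewhere, gives the lowest number of the three. The expected step of a 2.8-fold lower number from compound 1 to compound 4 (0.45 log units; beyond the scatter) is therefore downward, modestly beyond the scatter, toward a stronger inhibitor. For compound 4 the estimate is 500 nM, with a range from 150 nM to 1800 nM.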

Compound 4, half-maximal inhibitory concentration: 1450 nM
Estimate against measurement, compound 4: 2.9-fold (0.46 log units) below, and the stated range covers the measured number.
By their numbers in this assay, from the lowest: compound 2; then compounds 1, 4 and 3 (each within the scatter of the next).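

Replacing propyl with cyclohexyl on this aromatic nitrogen brings in a six-membered non-aromatic ring of carbon, yet in this assay the change is a 1.0-fold higher number from compound 1 to compound 4 (0.02 log units; within the scatter). For this pair, then, the position takes a ring in place of an open chain with no change that can be read from the numbers. Nothing measured alongside these compounds helps to explain this result.

Compound 2 differs from compound 4 in more than one place, so the compounds shown do not tell which of those differences goes with its number. Also open, as far as these compounds go, is whether a longer carbon chain, a smaller ring such as cyclopropyl, or a chain ending in an amine on this nitrogen would shift the number beyond the scatter.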